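The source may hold more compounds than are shown below. What is called first, only, known or untested is meant among the compounds shown, and "the series" means these compounds.

Measured in a functional assay on A549 cells (Homo sapiens) for inhibition, read by CCK-8 assay, with a stated time of 48 h; a lower number here means a stronger inhibitor, a higher number a weaker inhibitor:
- compound 1 `COc1cc(-c2ccnc3cc(-c4ccc(C)cc4)nn23)cc(OC)c1OC`: 3 nM
- compound 2 `COc1cc(-c2ccnc3cc(-c4cccc(C#N)c4)nn23)cc(OC)c1OC`: > 10000 nM, a limit of the assay and not a number
- compound 3 `COc1cc(-c2ccnc3cc(-c4ccc5cc[nH]c5c4)nn23)cc(OC)c1OC`: 170 nM

Of the two actual numbers, the higher belongs to compound 3. The gap on one side is a 57-fold higher number from compound 1 to compound 3 (1.75 log units; beyond the scatter), and the gap on the other is an at least 58-fold lower number from compound 2 to compound 3 (1.76 log units; beyond the scatter).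

Compound 4 `COc1cc(-c2ccnc3cc(-c4ccc5ccn(C)c5c4)nn23)cc(OC)c1OC` carries methyl in place of hydrogen on an aromatic nitrogen, turning 1H-indol-6-yl into 1-methyl-1H-indol-6-yl: methyl in place of hydrogen on an aromatic nitrogen. Among the measured compounds shown here, no measured step touches this nitrogen. All three measured steps replace the whole aryl group, and each is large, including an at least 3300-fold higher number from compound 1 to compound 2 (3.52 log units; beyond the scatter). They show that this group matters in this assay, but they do not size so small a change. The only hint of direction is that compound 1, with its 4-methylphenyl group, gives 3 nM. A far smaller step is therefore expected, probably towards a slightly lower number and possibly none beyond the scatter. The expected step is a 1.7-fold lower number from compound 3 to compound 4 (0.23 log units; within the scatter). Compound 4 is estimated at 100 nM, with an expected range of 25 nM to 500 nM.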

Compound 4, half-maximal inhibitory concentration: 829 nM
For compound 4 the middle estimate is 8.3-fold (0.92 log units) below the measured one, and the stated range ends below it.
By their numbers in this assay, from the lowest: compound 1; then compound 3; then compound 4. At a limit, above all of these: compound 2.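

In this assay, the methyl on the aromatic nitrogen of the five-membered ring is the first change shown that touches this nitrogen alone, and it gives a 4.9-fold higher number from compound 3 to compound 4 (0.69 log units; beyond the scatter). So this nitrogen responds to a change of one methyl, not only to replacement of the whole aryl group, and the change moves the number away from that of compound 1, with a 280-fold higher number from compound 1 to compound 4 (2.44 log units; beyond the scatter). One further step starts from a limit of the assay and not from a number, an at least 12-fold lower number from compound 2 to compound 4 (1.08 log units; beyond the scatter), and so gives only a bound: the limit of > 10000 nM in this assay, at which 1 of the 4 values shown sits.

On these data alone, whether the weaker result comes from losing the hydrogen or from adding the methyl remains open. So does the outcome of placing an ethyl group, or a longer chain ending in an amine, on this nitrogen.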